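Replacing 2,3-Dichlorophenyl with 4-Methoxyphenyl

The source may report more compounds than this note shows. Statements on the series, on what has been measured and on what is new or still open speak of the compounds shown alone.

In a functional assay on PC-3 cells (Homo sapiens) for antiproliferative activity, read by MTT assay, with a stated time of 72 h (on this read-out higher numbers stand for weaker inhibition and lower numbers for stronger inhibition), compound 1 `O=C(N/N=C/c1ccccc1)Nc1ccc(Oc2ccnc3[nH]ccc23)c(F)c1` gives 7940 nM. The result for compound 2 `O=C(N/N=C/c1cccc(Cl)c1Cl)Nc1ccc(Oc2ccnc3[nH]ccc23)c(F)c1` is "not active" (no number reported), so compound 2 has no single number and cannot be given an exact place on the scale. Compound 3 `COc1ccc(/C=N/NC(=O)Nc2ccc(Oc3ccnc4[nH]ccc34)c(F)c2)cc1` has yet to be measured. The structural change runs (4-methoxyphenyl in place of 2,3-dichlorophenyl on a carbon with a double bond to nitrogen), which puts 4-methoxyphenyl in place of 2,3-dichlorophenyl on a carbon with a double bond to nitrogen. Without a number at its starting point, this step cannot be given a firm size in this assay. The expected direction is toward measurable inhibition, though a result without a number remains possible. That expectation rests on compound 1, the one close relative with a number, at 7940 nM. The estimate for compound 3 is 8000 nM, with an expected range from 2500 nM to 30000 nM.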

Compound 3, half-maximal inhibitory concentration: 6730 nM
Beside the measured number, compound 3's estimate is 1.2-fold (0.08 log units) above it, within the range that was stated.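

In this assay compound 3 gives 6730 nM, a number where compound 2, with its 2,3-dichlorophenyl, gave none, so this swap on the carbon with a double bond to nitrogen reads only as a move from no number to a number, and the step has no size. Putting methoxy in place of hydrogen on an aromatic carbon gives a 1.2-fold lower number from compound 1 to compound 3 (0.07 log units; within the scatter), so at this place the added methoxy produces no change that can be told apart from ordinary scatter. No measurement offered here explains either result.

The compounds shown leave open whether a phenyl ring carrying a single chlorine would also give no number, or whether that outcome needs both chlorines. They also leave open how an amine or a carboxylic acid in place of the methoxy would read.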